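Changing the aryl group on the sulfonyl sulfur

The source may report more compounds than this note shows. Statements on the series, on what has been measured and on what is new or still open speak of the compounds shown alone.

Compound 1 `C=CCNC(=O)n1c(-c2ccc(OC)cc2)cc(=O)c2c(OC)cc(OC)cc21` gives 16000 nM in a functional assay on SUP-B15 cells (Homo sapiens) for antiproliferative activity, with a stated time of 72 h; on this read-out lower numbers stand for an effect already at smaller amounts and higher numbers for an effect only at larger amounts of compound.
Compound 2 `COc1ccc(-c2cc(=O)c3c(OC)cc(OC)cc3n2S(=O)(=O)c2cccc([N+](=O)[O-])c2)cc1` reaches only a limit in this assay, > 39600 nM.
Compound 3 `COc1ccc(-c2cc(=O)c3c(OC)cc(OC)cc3n2S(=O)(=O)c2c(F)c(F)c(F)c(F)c2F)cc1` gives 4100 nM in this assay.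

Compound 3 holds the lowest of the two numbers; compound 1 sits at a higher number beyond the scatter, and compound 2 stands at a limit (the limit of > 39600 nM in this assay, at which 1 of the 3 values shown sits). Among the measured compounds shown here, the one measured step that changes the aryl group on the sulfonyl sulfur is an at least 9.6-fold lower number from compound 2 to compound 3 (0.98 log units; beyond the scatter). Compound 4 `COc1ccc(-c2cc(=O)c3c(OC)cc(OC)cc3n2S(=O)(=O)c2cccc(Br)c2)cc1` differs from compound 3 by 3-bromophenyl in place of 2,3,4,5,6-pentafluorophenyl on a sulfonyl sulfur. Since compound 2, with 3-nitrophenyl in that place, reached only a limit (the limit of > 39600 nM in this assay, at which 1 of the 3 values shown sits), a higher number than compound 3 is expected for compound 4, though short of that limit. Compound 4 is therefore expected near 12000 nM, within 4000 nM to 40000 nM, which would be a 2.9-fold higher number from compound 3 to compound 4 (0.47 log units; beyond the scatter).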

Compound 4, half-maximal effective concentration: > 58600 nM
Compound 4: a limit, no number (the forecaster's own chance of this, stated with the estimate: 25%); middle value at least 4.8-fold (0.68 log units) from the limit.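

Compound 4 gives no number, only a limit: the limit of > 58600 nM in this assay, at which 1 of the 4 values shown sits. Putting 3-bromophenyl on the sulfonyl sulfur in place of 2,3,4,5,6-pentafluorophenyl gives an at least 14-fold higher number from compound 3 to compound 4 (1.15 log units; beyond the scatter), and (3-bromophenyl)sulfonyl in place of allylcarbamoyl on the aromatic nitrogen gives an at least 3.6-fold higher number from compound 1 to compound 4 (0.56 log units; beyond the scatter). Of the aryl groups shown on the sulfonyl sulfur, only 2,3,4,5,6-pentafluorophenyl gives a number, and the step between the two limits cannot be read.

Still open, going by these compounds, is whether a plain phenyl or a phenyl carrying a single fluoro group would give a number on the sulfonyl sulfur. The compounds shown also leave open what a methyl group in that place would give.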